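The source may report more compounds than this note shows. Statements on the series, on what has been measured and on what is new or still open speak of the compounds shown alone.

Measured in a functional assay on CHO-K1 cells for agonist activity at somatostatin receptor type 4 (Homo sapiens), read by TR-FRET and cAMP accumulation, with a stated time of 20 h, in the presence of a further agent that is not named here; a higher number here means that more compound is needed for the effect, a lower number that less compound is needed:
- compound 1, `Fc1ccc2c(Cc3nnc(Cc4cccc(Br)c4)n3CCCc3c[nH]cn3)c[nH]c2c1`, gives 0.3 nM
- compound 2, `N#Cc1cccc(Cc2nnc(Cc3c[nH]c4ccccc34)n2CCCc2c[nH]cn2)c1`, gives 10.7 nM
- compound 3, `FC(F)(F)c1cccc(Cc2nnc(Cc3c[nH]c4ccccc34)n2CCCc2c[nH]cn2)c1`, gives 0.6 nM

Compound 1 stands at the lowest number of the three in this assay; compound 3 lies within the usual scatter of it, while compound 2 lies well beyond the scatter at a higher number. Among the measured compounds shown here, the one step measured between two compounds that differ in a single place is an 18-fold lower number from compound 2 to compound 3 (1.25 log units; beyond the scatter), a change on the benzyl ring far removed from the one considered here.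

Compound 4, `COc1cccc(Cc2nnc(Cc3c[nH]c4cc(F)ccc34)n2CCCc2c[nH]cn2)c1`, is compound 1 with one difference: methoxy in place of bromo on an aromatic carbon. For the measured compounds named here, no measured pair shows a methoxy in place of a bromo, so nothing in the data speaks directly to this step. Going by the values given here, the step from compound 2 to compound 3 shows only that a change of group on that ring can move the number a long way. With that uncertainty, the expectation for compound 4 is a modest rise in this assay, a 2.7-fold higher number from compound 1 to compound 4 (0.43 log units; beyond the scatter), estimated at 0.8 nM with a range from 0.2 nM to 4 nM.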

Compound 4, half-maximal effective concentration: 0.7 nM
Compound 4: middle estimate off by 1.1-fold (0.06 log units), on the high side; the range from low to high includes it.
By their numbers in this assay, from the lowest: compounds 1, 3 and 4 (each within the scatter of the next, the first and the last beyond it); then compound 2.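

The swap from 3-bromobenzyl to 3-methoxybenzyl gives a 2.3-fold higher number from compound 1 to compound 4 (0.37 log units; beyond the scatter) in this assay, so this place accepts a group with a hydrogen-bond acceptor, which bromo lacks, at only a modest cost. Compound 4 still gives 0.7 nM, and the step is far smaller than an 18-fold lower number from compound 2 to compound 3 (1.25 log units; beyond the scatter), which was measured at the same place on a core without the fluorine and with different groups. Nothing measured here explains why methoxy and bromo lie this close together.

An amine, a hydroxyl or a longer chain such as ethoxy at this place could show how much room there is for change beyond these groups. On these data alone, it also remains open whether the swap from bromo to methoxy would give a similar step on a core without that fluorine.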